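Shared core series: chloro in place of nitro

A few compounds are considered here, and "the series" means these few. Any claim that something is new, unique, unknown or untested is made for them only; others in the source may bear on it.

Measured so far:
compound 1, `Clc1ccc(CSc2nnc(-c3ccncc3)n2-c2ccccc2)cc1`: 16900 nM
compound 2, `O=C(CSc1nnc(-c2ccncc2)n1-c1ccccc1)N/N=C/c1ccc([N+](=O)[O-])cc1`: 15900 nM

In a functional assay on HepG2 cells (Homo sapiens) for inhibition, read by MTT assay, with a stated time of 48 h (a higher number here means a weaker inhibitor, a lower number a stronger inhibitor), compound 1 gives 16900 nM. In this assay compound 2 gives 15900 nM. Compound 2 has the lowest number of the two, but its gap to compound 1 falls within the scatter, so the two compounds are not separated by this assay. No pair of measured compounds differs in only one place, so no single-point step is available from the numbers shown.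

Compound 3, `O=C(CSc1nnc(-c2ccncc2)n1-c1ccccc1)N/N=C/c1ccc(Cl)cc1`, is the next member to be measured in this assay. It differs from compound 2 by chloro in place of nitro on an aromatic carbon. Going by the values given here, no measured pair carries this change, so its size cannot be read from the existing data. Among the compounds with values here, with the two measured compounds sitting together and no step to lean on, the expectation is for no step beyond the scatter, in either direction.

The expected value for compound 3 in this assay is 15000 nM, with a range from 5000 nM to 45000 nM. The estimated step, a 1.1-fold lower number from compound 2 to compound 3 (0.03 log units; within the scatter), is expected to stay within the scatter.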

Compound 3, half-maximal inhibitory concentration: 11000 nM
Beside the measured number, compound 3's estimate is 1.4-fold (0.13 log units) above it; measured number inside the range.
By their numbers in this assay, from the lowest: compounds 3, 2 and 1 (each within the scatter of the next).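

In this assay, going by these compounds alone, the change from 4-nitrophenyl to 4-chlorophenyl gives the first single-point step, a 1.4-fold lower number from compound 2 to compound 3 (0.16 log units; within the scatter), so this exchange on the aromatic carbon para to a large group does not separate the two compounds. The group that leaves has 3 heavy atoms and 2 hydrogen-bond acceptors, and the group that enters has 1 heavy atom and no hydrogen-bond acceptors, yet this difference in make-up comes with no step beyond the scatter in this assay. No measurement available bears on why compound 2 and compound 3 sit so close.

On these data alone, whether an amine, a carboxylic acid or a methoxy group at this place on the aromatic ring would give a step beyond the scatter remains open. As far as these compounds go, compound 1 differs from compound 2 and compound 3 in more than one place, so steps involving it cannot be read, and the contribution of the chain that carries the 4-chlorophenyl in compound 3 also remains open.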